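Compound 3 to compound 4: 4-(trifluoromethyl)phenyl replaced by 3-nitrophenyl

The compounds below may be only part of what the source reports. "The series", "measured", "known", "first", "only" and "open" are said of these compounds alone.

In a functional assay on A549 cells (Homo sapiens) for antiproliferative activity, read by MTT assay, with a stated time of 72 h (a higher number here means a weaker inhibitor, a lower number a stronger inhibitor), compound 1 `O=C(CCCCCCc1nc(-c2cccc([N+](=O)[O-])c2)no1)NO` gives 10800 nM as a measured value, and compound 2 `Nc1ccccc1NC(=O)CCCCCCc1nc(-c2ccccc2)no1` gives 23900 nM as a measured value too. Compound 3 `Nc1ccccc1NC(=O)CCCCCCc1nc(-c2ccc(C(F)(F)F)cc2)no1` gives > 100000 nM which is a limit of the assay and not a number. The change to compound 4 `Nc1ccccc1NC(=O)CCCCCCc1nc(-c2cccc([N+](=O)[O-])c2)no1` puts 3-nitrophenyl in place of 4-(trifluoromethyl)phenyl on an aromatic carbon. Within the data shown here, the one measured step bearing on this group (an at least 4.1-fold higher number from compound 2 to compound 3 (0.62 log units; beyond the scatter)) came with trifluoromethyl in place of hydrogen on an aromatic carbon, and its full size stays open. The 3-nitrophenyl group also stands on compound 1 (10800 nM) though that compound has a different chain end. Loss of the trifluoromethyl group is therefore expected to bring a lower number, landing near compound 2 (23900 nM) rather than far past it. The expected step is an at least 3.3-fold lower number from compound 3 to compound 4 (0.52 log units; beyond the scatter) in this assay and another limit reading remains possible. For compound 4 the estimate is 30000 nM with an expected range from 10000 nM to 90000 nM in this assay as the working figure.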

Compound 4, half-maximal inhibitory concentration: 20200 nM
The estimate for compound 4 lay 1.5-fold (0.17 log units) above the measured number; the measured number falls inside the stated range.
By their numbers in this assay, from the lowest: compounds 1, 4 and 2 (each within the scatter of the next, the first and the last beyond it). At a limit, above all of these: compound 3.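

In this assay, 3-nitrophenyl in place of 4-(trifluoromethyl)phenyl gives an at least 4.9-fold lower number from compound 3 to compound 4 (0.69 log units; beyond the scatter), so this position on the shared core tolerates a substituted phenyl ring and still gives a readable number. On these data alone, compound 3 remains a limit of the assay and not a number, so the full size of that step stays open: the limit of > 100000 nM in this assay, at which 1 of the 4 values shown sits. The nitro group leaves no separable mark, with a 1.2-fold lower number from compound 2 to compound 4 (0.07 log units; within the scatter), and the chain end leaves none between the two 3-nitrophenyl compounds, with a 1.9-fold higher number from compound 1 to compound 4 (0.27 log units; within the scatter).

Open, as far as these compounds go, is whether the drop at compound 3 goes with the trifluoromethyl group itself or with its place on the phenyl ring. Also open, from the compounds shown here alone, is whether a methoxy group or a carboxylic acid on that ring would read with compound 2 and compound 4 or with compound 3.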